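A few compounds are considered here, and "the series" means these few. Any claim that something is new, unique, unknown or untested is made for them only; others in the source may bear on it.

Compound 1 `COc1cc(-c2nn(-c3cccc(NC(=O)Nc4cc(C(F)(F)F)cc(C(F)(F)F)c4)c3)cc2-c2ccncc2)ccc1Cl` and compound 2 `O=C(Nc1cccc(-n2cc(-c3ccncc3)c(-c3ccc(Cl)c(O)c3)n2)c1)Nc1cc(C(F)(F)F)cc(C(F)(F)F)c1` share one core and differ in a single spot. The difference is hydrogen in place of methyl on an oxygen on an aromatic ring Compound 3 `COc1cc(-c2nn(-c3cccc(NC(=O)Nc4ccc(Cl)c(C(F)(F)F)c4)c3)cc2-c2ccncc2)ccc1Cl` carries a different core; how its core differs from that of compound 1 is not broken down here. The unmeasured compound 4 `O=C(Nc1cccc(-n2cc(-c3ccncc3)c(-c3ccc(Cl)c(O)c3)n2)c1)Nc1ccc(Cl)c(C(F)(F)F)c1` is related to compound 3 by the same kind of change: hydrogen in place of methyl on an oxygen on an aromatic ring The place is described in the same words in both pairs.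

In a functional assay on MDA-MB-435 cells (Homo sapiens) for inhibition, read by sulforhodamine B assay, with a stated time of 48 h (a higher number here means a weaker inhibitor of growth, a lower number a stronger inhibitor of growth), compound 1 gives 886 nM and compound 2 gives 910 nM, so the change gave a 1.0-fold higher number from compound 1 to compound 2 (0.01 log units; within the scatter). In this assay compound 3 gives 683 nM, a number within the scatter of those of compound 1 and compound 2.

Because the same change gave a 1.0-fold higher number from compound 1 to compound 2 (0.01 log units; within the scatter), the step from compound 3 to compound 4 is expected to be about as small, a 1.0-fold higher number from compound 3 to compound 4 (0.01 log units; within the scatter). Compound 4 is therefore estimated at 700 nM, with a likely range from 350 nM to 1400 nM. This expectation rests on a single measured pair, so it remains uncertain.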

Compound 4, concentration for 50% growth inhibition: 660 nM
Compound 4: middle estimate off by 1.1-fold (0.03 log units), on the high side, and the stated range covers the measured number.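

Replacing methoxy with hydroxy on the aromatic ring makes no clear difference on the core of compound 3 in this assay, with a 1.0-fold lower number from compound 3 to compound 4 (0.01 log units; within the scatter). Set beside the earlier pair, the two cores agree: the same change on two cores in this assay, a 1.0-fold higher number (0.01 log units; within the scatter) from compound 1 to compound 2 and a 1.0-fold lower number (0.01 log units; within the scatter) from compound 3 to compound 4, 1.1-fold (0.03 log units) apart, within the scatter of two such steps. In these two pairs, then, the change carries from one core to the other with no visible effect on the number, but the data do not explain this, and two pairs in one cell line cannot show that the same would hold on other cores or in other assays.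

Only methoxy and hydroxy occupy this place in the compounds shown, so what an amine, a carboxylic acid or a longer chain such as ethoxy would do there remains open. Also open, on these data alone, is whether the change would stay this small on a core less closely related to these two.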